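The compounds below may be only part of what the source reports. "The series", "measured", "known", "first", "only" and "open" are said of these compounds alone.

Compound 1 `Oc1ccccc1-c1cc(-c2ccc(C(F)(F)F)cc2)cc(-c2ccccc2O)n1` and compound 2 `Oc1cccc(-c2cc(-c3ccc(C(F)(F)F)cc3)cc(-c3ccccc3O)n2)c1` share a core that carries a 4-(trifluoromethyl)phenyl group; compound 3 `Oc1cccc(-c2cc(-c3ccccc3OC(F)(F)F)cc(-c3ccccc3O)n2)c1` and compound 4 `Oc1cccc(-c2cc(-c3ccccc3OC(F)(F)F)cc(-c3cccc(O)c3)n2)c1` share a core that carries a 2-(trifluoromethoxy)phenyl group instead, and the difference between the two cores is not broken down here.

In a functional assay on HeLa cells (Homo sapiens) for inhibition (a lower number here means a stronger inhibitor, a higher number a weaker inhibitor), compound 1 gives > 50000 nM, which is a limit of the assay and not a number. Compound 2 likewise gives > 50000 nM in this assay, again a limit. The change 3-hydroxyphenyl in place of 2-hydroxyphenyl on an aromatic carbon therefore gives a step that the two limits leave unreadable from compound 1 to compound 2, because both values sit at the limit of > 50000 nM in this assay, at which 2 of the 3 values shown sit. For the measured compounds named here, compound 3 gives 15200 nM in this assay, the only number among the three measured compounds.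

The change from compound 3 to compound 4 is the same kind of change, (3-hydroxyphenyl in place of 2-hydroxyphenyl on an aromatic carbon), but its surroundings differ: here the place is meta to a 3-hydroxyphenyl group and meta to a large group, whereas from compound 1 to compound 2 it was meta to a 2-hydroxyphenyl group and meta to a 4-(trifluoromethyl)phenyl group. The earlier step gives no readable size, so the expectation rests on compound 3 alone, at 15200 nM, and on the possibility that the change costs something. For compound 4 the expected step is a 1.6-fold higher number from compound 3 to compound 4 (0.22 log units; within the scatter). Compound 4 is estimated at 25000 nM in this assay, with a range from 8000 nM to 80000 nM.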

Compound 4, half-maximal inhibitory concentration: 16700 nM
The estimate for compound 4 lay 1.5-fold (0.18 log units) above the measured number; the measured number falls inside the stated range.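

In this assay, putting 3-hydroxyphenyl in place of 2-hydroxyphenyl on the core with the 2-(trifluoromethoxy)phenyl group gives a 1.1-fold higher number from compound 3 to compound 4 (0.04 log units; within the scatter), so on this core the two hydroxyphenyl groups cannot be told apart. The same change on the core with the 4-(trifluoromethyl)phenyl group cannot be read, because compound 1 and compound 2 both sit at a limit of the assay, which is not a number: the limit of > 50000 nM in this assay, at which 2 of the 4 values shown sit. For the compounds shown here, the series therefore offers only one readable step for this change, which shows how it behaves on one core but cannot show whether that behaviour carries over to another.

The compounds shown leave open whether a different group on the ring, such as an amine or a carboxylic acid in place of the hydroxyl, would move the number beyond the scatter. They also leave open whether the hydroxyl at a third position on that ring, as in 4-hydroxyphenyl, would behave like the two tested here.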